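Expected Cytotoxicity of a Naphthyl-Bearing Analogue

The source may hold more compounds than are shown below. What is called first, only, known or untested is meant among the compounds shown, and "the series" means these compounds.

Compound 1 `CCCCOc1ccc(-c2nc3ncccn3c2NCCC)cc1`: > 100000 nM
Compound 2 `CCCCOc1ccc(-c2nc3ncccn3c2Nc2ccc(F)cc2)cc1`: > 100000 nM
Compound 3 `CCCCOc1ccc(-c2nc3ncccn3c2Nc2ccccc2)cc1`: 100000 nM

All three measured compounds share the core shown for compound 1 and were tested in a toxicity assay on A549 cells (Homo sapiens) for cytotoxicity, read by luminescence and CellTiter-Glo, with a stated time of 48 h; a lower number here means that less compound is tolerated, a higher number that more compound is tolerated. For compound 1 the result is only a limit of the assay, > 100000 nM, so where it stands is not pinned to a number. The same holds for compound 2, whose value > 100000 nM is likewise a limit. Compound 3 gives 100000 nM, a number that sits at the edge of the range reached. Two of the three results rest at the limit of > 100000 nM in this assay, at which 2 of the 3 values shown sit.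

Compound 4 `CCCCOc1ccc(-c2nc3ncccn3c2NCc2ccc3ccccc3c2)cc1` differs from compound 1 by naphthalen-2-yl in place of ethyl on a saturated chain carbon bound to a nitrogen on an aromatic ring. Two measured steps start from compound 1: a step that the two limits leave unreadable from compound 1 to compound 2 and a number no higher from compound 1 to compound 3 (the limit leaves the size open). Both swap the propyl arm for a larger group, and neither shows a readable change. Because every value sits at or against (the limit of > 100000 nM in this assay, at which 2 of the 3 values shown sit), no direction can be read for the new step either. Compound 4 is therefore expected to give about 100000 nM, from 40000 nM to 300000 nM, most likely once more as a limit rather than a number. The step of a number no higher from compound 1 to compound 4 (the limit leaves the size open) is thus expected to stay within the scatter.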

Compound 4, half-maximal cytotoxic concentration: 33000 nM
Compound 4: middle estimate off by 3.0-fold (0.48 log units), on the high side; the whole stated range lies above it.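

In this assay, this position proves able to move the read-out: naphthalen-2-yl in place of ethyl on a saturated chain carbon bound to a nitrogen on an aromatic ring gives an at least 3.0-fold lower number from compound 1 to compound 4 (0.48 log units; beyond the scatter), which means that the cells tolerate less of compound 4. The value of compound 1, > 100000 nM, is a limit and not a number. This is the only step in the set that can be read as a change beyond the scatter, and the earlier steps cannot be read because the results sit against the ceiling of the assay: the limit of > 100000 nM in this assay, at which 2 of the 4 values shown sit.

From the compounds shown here alone, what remains open is which feature of the entering group matters, the two six-membered aromatic rings or simply the larger count of carbon atoms, and a single phenyl ring or a longer chain such as hexyl on the same carbon would help to separate the two. Going by these compounds, it also remains open whether an amine or a carboxylic acid on the naphthalene rings would keep or reverse the lower number, and whether the same change would lower the number in other cell types.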